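A few compounds are considered here, and "the series" means these few. Any claim that something is new, unique, unknown or untested is made for them only; others in the source may bear on it.

Values measured in a functional assay on M21 cells (Homo sapiens) for antiproliferative activity, read by sulforhodamine B assay, with a stated time of 48 h (a lower number here means a stronger inhibitor, a higher number a weaker inhibitor), are as follows.

- compound 1 `CCc1ccccc1NS(=O)(=O)c1ccc(N2CCNC2=O)cc1` gives 180 nM
- compound 2 `O=C1NCCN1c1ccc(S(=O)(=O)Nc2ccc(I)cc2)cc1` gives 260 nM
- compound 3 `O=C1NCCN1c1ccc(S(=O)(=O)Nc2ccc(Cl)cc2)cc1` gives 90 nM

In this assay compound 3 sits with compound 1 at the low end of these three numbers, and the gap between them is a 2.0-fold lower number from compound 1 to compound 3 (0.30 log units; within the scatter) on the measured record. Compound 2 lies clear of that pair, with a 2.9-fold lower number from compound 2 to compound 3 (0.46 log units; beyond the scatter) as the step to compound 3.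

Compound 4 `Cc1ccc(C)c(NS(=O)(=O)c2ccc(N3CCNC3=O)cc2)c1` has not yet been measured. It differs from compound 3 as follows: 2,5-dimethylphenyl in place of 4-chlorophenyl on a sulfonamide nitrogen.

Among the measured compounds shown here, no measured step makes exactly this exchange. For the measured compounds named here, the closest guide is compound 1 at 180 nM as the only measured compound without a halogen on that aryl group. The step of a 2.0-fold lower number from compound 1 to compound 3 (0.30 log units; within the scatter) therefore bears most directly, while a 1.4-fold higher number from compound 1 to compound 2 (0.16 log units; within the scatter) shows another aryl exchange that stayed within the scatter. A small rise in the number is expected on leaving compound 3, and no change beyond the scatter is expected. The expected step is a 1.7-fold higher number from compound 3 to compound 4 (0.22 log units; within the scatter) and rests on this single comparison. For compound 4 the estimated value is 150 nM with 60 nM to 400 nM as its expected range.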

Compound 4, half-maximal inhibitory concentration: 27 nM
For compound 4 the middle estimate is 5.6-fold (0.74 log units) above the measured one; measured number outside the range, below it.
By their numbers in this assay, from the lowest: compound 4; then compounds 3, 1 and 2 (each within the scatter of the next, the first and the last beyond it).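

Changing the aryl group on the sulfonamide nitrogen can move the number further than the first three compounds showed: in this assay, the exchange of 4-chlorophenyl for 2,5-dimethylphenyl gives a 3.3-fold lower number from compound 3 to compound 4 (0.52 log units; beyond the scatter), which makes compound 4 the strongest of the four. Among the compounds shown here, the earlier compounds gave no sign of this, as compound 1, the only other compound without a halogen on that aryl group, had not improved on compound 3; the two non-halogen groups also differ clearly from each other, with a 6.7-fold lower number from compound 1 to compound 4 (0.82 log units; beyond the scatter), and the widest gap in the set is a 9.6-fold lower number from compound 2 to compound 4 (0.98 log units; beyond the scatter). Nothing at hand accounts for the advantage of 2,5-dimethylphenyl over the other three aryl groups.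

The compounds shown leave open whether both methyl groups of 2,5-dimethylphenyl are needed for this level of activity, or whether one alone would give the same number. They also leave open whether a methoxy group, an amine or a carboxylic acid on that aryl ring would keep the number as low as that of compound 4.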